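Aryl swap on the amidoxime: compound 1 to compound 3

A few compounds are considered here, and "the series" means these few. Any claim that something is new, unique, unknown or untested is made for them only; others in the source may bear on it.

Within the data shown here, compound 1 `O=[N+]([O-])c1ccc(N/C(=N\O)c2ccccc2Br)c2nonc12` gives 80 nM in an assay on isolated protein for inhibition of Indoleamine 2,3-dioxygenase 1 (Homo sapiens), read by spectrophotometry, with a stated time of 1 h (a higher number here means a weaker inhibitor, a lower number a stronger inhibitor), and stands highest of the two numbers so far. Compound 2 `O=[N+]([O-])c1ccc(N/C(=N\O)c2cccc(F)c2)c2nonc12` gives 75 nM in this assay and the step of a 1.1-fold lower number from compound 1 to compound 2 (0.03 log units; within the scatter) lies within the scatter. Compound 3 `O=[N+]([O-])c1ccc(N/C(=N\O)c2ccc(F)cc2)c2nonc12` is not yet measured and differs from compound 1 by 4-fluorophenyl in place of 2-bromophenyl on a carbon with a double bond to nitrogen. Among the measured compounds shown here, the one measured step that bears on this change is a 1.1-fold lower number from compound 1 to compound 2 (0.03 log units; within the scatter) and it lies within the scatter, so in this assay no step beyond the scatter is expected from compound 1 to compound 3. Compound 3 is therefore expected to give about 85 nM with a range from 40 nM to 180 nM and an expected step of a 1.1-fold higher number from compound 1 to compound 3 (0.03 log units; within the scatter) in this assay.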

Compound 3, half-maximal inhibitory concentration: 100 nM
Estimate against measurement, compound 3: 1.2-fold (0.07 log units) below; measured number inside the range.
By their numbers in this assay, from the lowest: compounds 2, 1 and 3 (each within the scatter of the next).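

Replacing 2-bromophenyl with 4-fluorophenyl gives a 1.3-fold higher number from compound 1 to compound 3 (0.10 log units; within the scatter), and replacing 3-fluorophenyl with 4-fluorophenyl gives a 1.3-fold higher number from compound 2 to compound 3 (0.12 log units; within the scatter). On this carbon with a double bond to nitrogen, 2-bromophenyl, 3-fluorophenyl and 4-fluorophenyl therefore cannot be told apart in this assay, so a third halogenated aryl group adds no step beyond the scatter. No measurement available here accounts for this flat result.

All three aryl groups carry a single halogen. Open, going by these compounds, is whether a methoxy group, an amine or a carboxylic acid on the ring, or a cyclohexyl group in place of the aryl ring, would keep the number in this range.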